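A few compounds are considered here, and "the series" means these few. Any claim that something is new, unique, unknown or untested is made for them only; others in the source may bear on it.

Working notes on the series, read in an ADME assay on Caco-2 cells (Homo sapiens) for permeability, read by LC-MS, in the apical to basolateral direction, with a stated time of 95 min; on this read-out higher numbers stand for higher permeability and lower numbers for lower permeability. Compound 1 (`CN(C)c1cc(OCc2cc(F)c(Oc3ccc(Cl)c(C(F)(F)F)c3)c(F)c2)nc(=O)n1C`) gives 0.65 10^-6 cm/s. Within the data shown here, compound 2 (`CCOC(=O)CN(C)c1cc(OCc2cc(F)c(Oc3ccc(Cl)c(C(F)(F)F)c3)c(F)c2)nc(=O)n1C`) gives 0.32 10^-6 cm/s, the lower of the two numbers so far.

The next comparison is compound 3 (`Cn1c(N2CCCC2)cc(OCc2cc(F)c(Oc3ccc(Cl)c(C(F)(F)F)c3)c(F)c2)nc1=O`), with pyrrolidin-1-yl in place of ((ethoxycarbonyl)methyl)(methyl)amino on an aromatic carbon.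

Among the measured compounds shown here, only one measured step bears on this change: a 2.0-fold lower number from compound 1 to compound 2 (0.31 log units; beyond the scatter), a modest step, with ethoxycarbonyl in place of hydrogen on a saturated chain carbon bound to a nitrogen on an aromatic ring. Compound 3 has no ethoxycarbonyl group, as is also the case for compound 1, so the expectation is anchored on compound 1 at 0.65 10^-6 cm/s. For the measured compounds named here, no measured compound carries pyrrolidin-1-yl, so the range is kept wide.

In this assay a modest step upward is expected, about equal in size to the measured one and opposite in direction. The expected step is a 2.0-fold higher number from compound 2 to compound 3 (0.31 log units; beyond the scatter). For compound 3 the estimated value is 0.65 10^-6 cm/s, with an expected range from 0.25 10^-6 cm/s to 1.6 10^-6 cm/s.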

Compound 3, apparent permeability: 0.08 10^-6 cm/s
Compound 3: middle estimate off by 8.1-fold (0.91 log units), on the high side; measured number outside the range, below it.
By their numbers in this assay, from the lowest: compound 3; then compound 2; then compound 1.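

In this assay, among these compounds, the number at this aromatic carbon depends on more than the presence of ethoxycarbonyl: exchanging dimethylamino for pyrrolidin-1-yl, with no ester in either compound, gives an 8.1-fold lower number from compound 1 to compound 3 (0.91 log units; beyond the scatter), a step that places compound 3 lowest of the three by the printed values. Removing ((ethoxycarbonyl)methyl)(methyl)amino did not restore the higher number either, as pyrrolidin-1-yl in its place gives a 4.0-fold lower number from compound 2 to compound 3 (0.60 log units; beyond the scatter), so the lack of an ester alone does not set the level here, and the lower number for compound 2 relative to compound 1 cannot be read as a general penalty for larger groups at this carbon, since pyrrolidin-1-yl has fewer heavy atoms than the group it replaces. Nothing measured alongside these numbers bears on the reason for the drop.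

The compounds shown leave open whether the low number belongs to the five-membered ring itself or to any cyclic amine at this carbon, a question that azetidin-1-yl, piperidin-1-yl or morpholin-4-yl would address, with diethylamino as the open-chain comparison. Also open, from the compounds shown here alone, is how a carboxylic acid in place of the ethyl ester would read on the chain of compound 2.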